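The source may hold more compounds than are shown below. What is called first, only, known or untested is meant among the compounds shown, and "the series" means these compounds.

Compound 1, `COc1ccc(Oc2ccc3cc(NC(=O)c4ccc(OC(C)=O)c(CC=C(C)C)c4)c(=O)oc3c2C)cc1`: 18200 nM
Compound 2, `COc1ccc(Oc2ccc3cc(NC(=O)c4ccc(O)c(CC=C(C)C)c4)c(=O)oc3c2C)cc1`: 6510 nM

Within the data shown here, in a functional assay on MCF7 cells (Homo sapiens) for antiproliferative activity (a higher number here means a weaker inhibitor, a lower number a stronger inhibitor), compound 2 gives the lowest of the two numbers measured so far; its nearest neighbour is compound 1, reached through a 2.8-fold lower number from compound 1 to compound 2 (0.45 log units; beyond the scatter), a modest step. Compound 3, `COc1ccc(Nc2ccc3cc(NC(=O)c4ccc(O)c(CC=C(C)C)c4)c(=O)oc3c2C)cc1`, differs from compound 2 by (4-methoxyphenyl)amino in place of 4-methoxyphenoxy on an aromatic carbon. Among the measured compounds shown here, the single measured step concerns a different group on the shared core, so no measured step bears directly on this change, and no shift beyond the scatter is expected in this assay. Compound 3 is therefore estimated at 6500 nM, with a range from 2500 nM to 17000 nM, which means an expected step of a 1.0-fold lower number from compound 2 to compound 3 (0.00 log units; within the scatter).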

Compound 3, half-maximal inhibitory concentration: > 100000 nM
Compound 3 was reported as a limit; the forecaster's own chance of this, stated with the estimate: 5%; at least 15-fold (1.18 log units) between middle value and limit.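

The earlier step concerned only the acetyl and hydrogen on the oxygen, whereas this one shows that the other end of the molecule is far from indifferent in this assay. Both groups have 9 heavy atoms, yet (4-methoxyphenyl)amino in place of 4-methoxyphenoxy, on the aromatic carbon ortho to a methyl group, gives an at least 15-fold higher number from compound 2 to compound 3 (1.18 log units; beyond the scatter). The value of compound 3 is a limit: the limit of > 100000 nM in this assay, at which 1 of the 3 values shown sits.

The compounds shown leave open whether the nitrogen itself or its hydrogen accounts for this loss. A tertiary amine with a methyl on that nitrogen, or a sulfur or methylene link, would help separate the two.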